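Cyclohexanone bis-benzylidene series: fibroblast cytotoxicity notes

This account rests on a few compounds, and the source may have more. Where it says the series, first, only, none or still open, it means among the compounds named here.

Measured so far, in an ADME assay on NHDF cells (Homo sapiens) for cytotoxicity, read by MTT assay, with a stated time of 72 h; a higher number here means a weaker inhibitor, a lower number a stronger inhibitor:
compound 1, `COc1cccc(/C=C2\CCC/C(=C\c3cccc(OC)c3OC)C2=O)c1`, gives 16400 nM
compound 2, `COc1cccc(/C=C2\CCC/C(=C\c3cc(OC)c(OC)c(OC)c3)C2=O)c1OC`, gives 7900 nM
compound 3, `COc1ccc(/C=C2\CCC/C(=C\c3cccc(Cl)c3)C2=O)cc1OC`, gives 11900 nM

Compound 3 stands second highest of the three numbers in this assay. Its nearest neighbour is compound 1, whose higher number lies within the scatter of compound 3; its furthest is compound 2, whose lower number also lies within the scatter. Among the compounds with values here, the three measured compounds therefore show no separation that can be read as an order, and none of them differs from another in only one place, so no single-change step is known.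

Compound 4, `COc1ccc(/C=C2\CCC/C(=C\c3ccc(O)c(O)c3)C2=O)cc1OC`, is not yet measured. It differs from compound 3 as follows: 3,4-dihydroxyphenyl in place of 3-chlorophenyl on a double-bonded chain carbon bound to a double-bonded ring carbon.

Within the data shown here, with no measured step to lean on, the only reference is the narrow spread of compounds 1, 2 and 3 in this assay. On that basis the step of a 1.0-fold higher number from compound 3 to compound 4 (0.00 log units; within the scatter) is expected to stay within the scatter, with no clear direction. For compound 4 the number in this assay is estimated at 12000 nM, with a plausible range from 4000 nM to 36000 nM.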

Compound 4, half-maximal inhibitory concentration: 25200 nM
For compound 4 the middle estimate is 2.1-fold (0.32 log units) below the measured one; measured number inside the range.
By their numbers in this assay, from the lowest: compounds 2, 3, 1 and 4 (each within the scatter of the next, the first and the last beyond it).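

In this assay, within the data shown here, replacing 3-chlorophenyl with 3,4-dihydroxyphenyl on a double-bonded chain carbon bound to a double-bonded ring carbon gives a 2.1-fold higher number from compound 3 to compound 4 (0.33 log units; beyond the scatter), a modest step and the first single-place change. Among these compounds, it shows that this position is not indifferent to the group it carries, something the earlier compounds could not show, since none of them differed from another in only one place. The entering group brings hydrogen-bond donors and acceptors and the leaving group has none, but this single pair cannot link the step to those counts, and no supporting data bear on the reason for the step.

From the compounds shown here alone, it remains open whether the step follows from the loss of chlorine, from the gain of the hydroxyl groups, or from both together, and a phenyl group bearing a single hydroxyl, an amine or a carboxylic acid at this position would help to separate these readings. Also open, going by these compounds, is whether the same change gives a step of similar size and direction with other groups on the far side of the shared core.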